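Chloro scan on a quinolinone amine series: cytotoxicity notes

The source may report more compounds than this note shows. Statements on the series, on what has been measured and on what is new or still open speak of the compounds shown alone.

Measured compounds:
- compound 1 `Cc1ccc2[nH]c(=O)c(CN(Cc3ccc(N(C)C)cc3)Cc3ccc(C(C)(C)C)cc3)cc2c1` — > 5000 nM in this assay, a limit
- compound 2 `Cc1ccc2[nH]c(=O)c(CN(Cc3ccc(C(C)(C)C)cc3)Cc3ccc(N(C)C)c(Cl)c3)cc2c1` — > 10000 nM, a limit
- compound 3 `COc1ccc([C@H](C)N(Cc2ccc(OC(F)(F)F)cc2)Cc2cc3ccccc3[nH]c2=O)cc1` — > 10000 nM, a limit

In a toxicity assay on MDCK cells (Canis lupus familiaris) for cytotoxicity, read by crystal violet staining, with a stated time of 48 h (a higher number here means that more compound is tolerated, a lower number that less compound is tolerated), compound 1 reaches only a limit, > 5000 nM. Compound 2 likewise stops at a limit, > 10000 nM. The change between them is chloro in place of hydrogen on an aromatic carbon, and the step that the two limits leave unreadable from compound 1 to compound 2 cannot be read, because the limit of > 10000 nM in this assay, at which 2 of the 3 values shown sit, and the limit of > 5000 nM in this assay, at which 1 of the 3 values shown sits, cap both values.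

Compound 3 also gives only a limit in this assay, > 10000 nM. The difference between the core of compound 3 and the core of compound 1 is not broken down here. Compound 4 `COc1ccc([C@H](C)N(Cc2ccc(OC(F)(F)F)cc2)Cc2cc3cc(Cl)ccc3[nH]c2=O)cc1` is not yet measured; it differs from compound 3 by chloro in place of hydrogen on an aromatic carbon. This is the same kind of change as from compound 1 to compound 2, but not the same: there the chloro sits ortho to a dimethylamino group and meta to a large group, here it sits on a ring that is part of a fused or bridged system of two rings, meta and para to a fused ring.

The step that the limit leaves unreadable from compound 3 to compound 4 is expected to be small, since compound 3 already sits at a limit, > 10000 nM, and compound 2 sits at the limit of > 10000 nM in this assay, at which 2 of the 3 values shown sit, after the same kind of change. Compound 4 is therefore estimated at 15000 nM in this assay, with a range from 5000 nM to 50000 nM, most likely again reported only as a limit.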

Compound 4, half-maximal cytotoxic concentration: > 10000 nM
Compound 4 ended at the assay's limit (the forecaster's own chance of this, stated with the estimate: 80%); the middle value lies beyond the limit too.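

Compound 3 and compound 4 both stop at a limit in this assay, so chloro in place of hydrogen on an aromatic carbon gives no readable step between them: the limit of > 10000 nM in this assay, at which 3 of the 4 values shown sit.

The compounds shown leave open at what concentration any of them becomes cytotoxic, and whether chloro in place of hydrogen changes that concentration at all.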